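Hydroxyphenyl placement on the ring nitrogen: compound 4

This account rests on a few compounds, and the source may have more. Where it says the series, first, only, none or still open, it means among the compounds named here.

Compound 3 `CC1(C)[C@H]2CC[C@]1(C)N(Cc1cn(-c3ccc(F)cc3)nn1)C(=O)C2` gives 40 nM in a functional assay on LoVo cells (Homo sapiens) for inhibition, read by MTT assay, with a stated time of 24 h (on this read-out lower numbers stand for stronger inhibition and higher numbers for weaker inhibition), the lowest of the three numbers. Compound 2 `COc1ccc(-n2cc(CN3C(=O)C[C@@H]4CC[C@@]3(C)C4(C)C)nn2)cc1` gives 70 nM, within the scatter (a 1.8-fold lower number from compound 2 to compound 3 (0.24 log units; within the scatter)), while compound 1 `CC1(C)[C@H]2CC[C@]1(C)N(Cc1cn(-c3ccccc3O)nn1)C(=O)C2` gives 540 nM, a gap well beyond it (a 14-fold lower number from compound 1 to compound 3 (1.13 log units; beyond the scatter)). Compound 4 `CC1(C)[C@H]2CC[C@]1(C)N(Cc1cn(-c3cccc(O)c3)nn1)C(=O)C2` carries 3-hydroxyphenyl in place of 4-fluorophenyl on an aromatic nitrogen. Among the measured compounds shown here, no measured step places a hydroxyl at this position; the nearest guides are a 14-fold lower number from compound 1 to compound 3 (1.13 log units; beyond the scatter) and a 7.7-fold lower number from compound 1 to compound 2 (0.89 log units; beyond the scatter), both marking 2-hydroxyphenyl as the weakest aryl seen. A return toward the number of compound 1 is therefore expected, though smaller than a 14-fold lower number from compound 1 to compound 3 (1.13 log units; beyond the scatter) reversed, since the hydroxyl now sits elsewhere. Compound 4 is estimated at 150 nM, range 40 nM to 600 nM, an expected step of a 3.8-fold higher number from compound 3 to compound 4 (0.57 log units; beyond the scatter).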

Compound 4, half-maximal inhibitory concentration: 410 nM
Compound 4: middle estimate off by 2.7-fold (0.44 log units), on the low side; measured number inside the range.
By their numbers in this assay, from the lowest: compounds 3 and 2 (each within the scatter of the next); then compounds 4 and 1 (each within the scatter of the next).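

Shifting the hydroxyl around the phenyl ring does not separate the two hydroxyphenyl compounds (a 1.3-fold lower number from compound 1 to compound 4 (0.12 log units; within the scatter)), so the high number of compound 1 is not peculiar to 2-hydroxyphenyl. Both steps from the non-hydroxylated aryls are beyond the scatter (a 10-fold higher number from compound 3 to compound 4 (1.01 log units; beyond the scatter); a 5.9-fold higher number from compound 2 to compound 4 (0.77 log units; beyond the scatter)), which places 3-hydroxyphenyl clearly behind 4-fluorophenyl and 4-methoxyphenyl. No measured evidence is at hand to explain this result.

Still open, going by these compounds, is whether an aminophenyl or a carboxyphenyl on this aromatic nitrogen would group with compound 1 and compound 4 or with compound 2 and compound 3.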